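The source may report more compounds than this note shows. Statements on the series, on what has been measured and on what is new or still open speak of the compounds shown alone.

Measured in a functional assay on HT-1080 cells (Homo sapiens) for cytotoxicity, read by MTT assay, with a stated time of 72 h; on this read-out higher numbers stand for weaker inhibition and lower numbers for stronger inhibition:
- Compound 1 `COc1cccc(/C=C2\CCC/C(=C\c3ccc(O)cc3)C2=O)c1OC`: > 20000 nM
- Compound 2 `COc1cccc(/C=C2\CCC/C(=C\c3cc(Cl)cc(Cl)c3)C2=O)c1OC`: 6100 nM
- Compound 3 `COc1ccc(/C=C2\CCC/C(=C\c3ccc(Cl)cc3)C2=O)cc1OC`: 4800 nM

The value for compound 1 is a limit of the assay and not a number. Compound 3 stands at 4800 nM, within the scatter of compound 2 at 6100 nM. Compound 4 `COc1cccc(/C=C2\CCC/C(=C\c3ccc(OC)c(OC)c3)C2=O)c1` has 3-methoxyphenyl in place of 4-chlorophenyl on a double-bonded chain carbon bound to a double-bonded ring carbon. Within the data shown here, one measured step bears on this change: with 3,5-dichlorophenyl in place of 4-hydroxyphenyl at that place, an at least 3.2-fold lower number from compound 1 to compound 2 (0.51 log units; beyond the scatter). The entering group in compound 4 also lacks chlorine, as the group in compound 1 does, so a modest move to a higher number is expected in this assay. The expected step is a 2.1-fold higher number from compound 3 to compound 4 (0.32 log units; beyond the scatter). For compound 4 the estimated value is 10000 nM, with an expected range of 4000 nM to 20000 nM.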

Compound 4, half-maximal inhibitory concentration: 4600 nM
Compound 4: the middle estimate sits 2.2-fold (0.34 log units) above what was measured; measured number inside the range.
By their numbers in this assay, from the lowest: compounds 4, 3 and 2 (each within the scatter of the next). At a limit, above all of these: compound 1.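

At this place, on a double-bonded chain carbon bound to a double-bonded ring carbon, this assay does not separate the two groups: a 1.0-fold lower number from compound 3 to compound 4 (0.02 log units; within the scatter). Among these compounds, the entering 3-methoxyphenyl carries no chlorine, so chlorine on this group is not required for a value in this range, which the earlier compounds did not show. Nothing measured here gives a cause for this result. On these data alone, what an amine or a carboxylic acid on the phenyl group would do at this place remains open.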